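A Methyl Leaves the Aryl Oxygen: Compound 2 to Compound 3

The compounds below may be only part of what the source reports. "The series", "measured", "known", "first", "only" and "open" are said of these compounds alone.

Of the compounds shown here, two built on a shared core have so far been measured in a functional assay on OVCAR-5 cells (Homo sapiens) for cytotoxicity, read by sulforhodamine B assay, with a stated time of 48 h, tested at 0.001 uM; a lower number here means a stronger effect, a higher number a weaker effect of the compound at the concentration tested. Compound 1 `Cc1cc(O)cc(-c2nn(CC#N)cc2-c2ccnc(-c3ccc(Oc4ccccc4)cc3)c2)c1` carries a phenoxyphenyl group and a hydroxy group on its outer phenyl ring; in this assay compound 1 gives 72%. Compound 2 `COc1cc(C)cc(-c2nn(CC#N)cc2-c2ccnc(-c3ccc(N(C)C)cc3)c2)c1` carries a dimethylamino group and a methoxy group in the corresponding places; in this assay compound 2 gives 98%, the highest of the two numbers and therefore the weaker effect, separated from compound 1 by a gap that lies beyond the usual scatter. Compound 1 and compound 2 differ in two places at once, so their two values alone do not tell what each change contributes.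

Compound 3 `Cc1cc(O)cc(-c2nn(CC#N)cc2-c2ccnc(-c3ccc(N(C)C)cc3)c2)c1` takes a single step away from compound 2: hydrogen in place of methyl on an oxygen on an aromatic ring. Cut one bond further out, the change reads methoxy to hydroxy, or 3-methoxy-5-methylphenyl to 3-hydroxy-5-methylphenyl. Among the measured compounds shown here, no measured pair isolates this change, so its size is not known from the data. Compound 3 now shares its hydroxy group with compound 1, whose value 72% is the lower one, and the author expects a modest downward step, of the size a number 10 percentage points lower from compound 2 to compound 3 (within the scatter), though one that may stay within the scatter. Compound 3 is thus estimated at 88%, within a range from 70% to 100%.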

Compound 3, a percentage reported as activity, at one concentration (the size of the read-out at that concentration, not a potency): 96%
Compound 3: middle estimate off by 8 percentage points, on the low side, within the range that was stated.
By their numbers in this assay, from the lowest: compound 1; then compounds 3 and 2 (each within the scatter of the next).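

Removing the methyl from the aryl oxygen leaves this assay with a number 2 percentage points lower from compound 2 to compound 3 (within the scatter), so in this dimethylamino series, methoxy and hydroxy on the 3-position-bearing outer ring cannot be told apart at the concentration tested. Compound 3 also gives the first single-place comparison with compound 1: with the hydroxy group held constant, dimethylamino in place of phenoxy on an aromatic carbon gives a number 24 percentage points higher from compound 1 to compound 3 (beyond the scatter), a step beyond the scatter, and this is the only change shown here to move the read-out beyond it. The data offer no measured property that would account for either step.

The compounds shown leave open whether the silence of the methoxy to hydroxy change would hold with phenoxy on the other end of the molecule, since that change has been read only with dimethylamino in place. They also leave open how an ethoxy group or an amine at the aryl oxygen position would read, and whether a benzyloxy group or a morpholine in place of phenoxy would keep the lower number of compound 1, or lose it as dimethylamino does.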